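Chloro for Methyl: Estimating the Fourth Analogue

A few compounds are considered here, and "the series" means these few. Any claim that something is new, unique, unknown or untested is made for them only; others in the source may bear on it.

Three compounds have been measured in a functional assay on HeLa cells (Homo sapiens) for cytotoxicity, in the presence of a further agent that is not named here; a lower number here means a stronger inhibitor, a higher number a weaker inhibitor:

Compound 1, `Clc1ccc(-c2cc(-c3ccc(Cl)o3)cc(-c3ccsc3)n2)cc1`, gives 8410 nM.
Compound 2, `Clc1ccc(-c2cc(-c3ccoc3)cc(-c3cccs3)n2)cc1`, gives 5530 nM.
Compound 3, `Cc1ccc(-c2cc(-c3ccc(Cl)o3)cc(-c3cccs3)n2)cc1`, gives 16300 nM.

Compound 3 carries the highest number of the three. Its gap to compound 1 lies within the scatter of repeated measurements, so the two cannot be ranked against each other; its gap to compound 2 lies beyond the scatter, so compound 2 is the stronger inhibitor of that pair.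

Compound 4, `Clc1ccc(-c2cc(-c3ccc(Cl)o3)cc(-c3cccs3)n2)cc1`, has not yet been measured in this assay. It differs from compound 3 in one place: chloro in place of methyl on an aromatic carbon. Among the measured compounds shown here, no two measured compounds differ only in this way, so the size of this step has not been seen directly. Compound 1 also carries a chlorophenyl group, but it differs from compound 3 in a second place as well; the value of compound 1, 8410 nM, can therefore only hint at the outcome.

For the step from compound 3 to compound 4 a small move toward a lower number is expected, a 1.8-fold lower number from compound 3 to compound 4 (0.26 log units; within the scatter), quite possibly within the scatter. Compound 4 is therefore expected to give about 9000 nM in this assay, with a likely range from 4000 nM to 20000 nM.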

Compound 4, half-maximal inhibitory concentration: 21300 nM
Compound 4: middle estimate off by 2.4-fold (0.37 log units), on the low side, outside the stated range (above it).
By their numbers in this assay, from the lowest: compounds 2, 1, 3 and 4 (each within the scatter of the next, the first and the last beyond it).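

Read directly in this assay, the change from 4-methylphenyl to 4-chlorophenyl gives a 1.3-fold higher number from compound 3 to compound 4 (0.12 log units; within the scatter) and so does not separate the two groups at this position, at least with the rest of compound 3 in place. The other two comparisons do register: thiophen-2-yl in place of thiophen-3-yl gives a 2.5-fold higher number from compound 1 to compound 4 (0.40 log units; beyond the scatter) and 5-chlorofuran-2-yl in place of furan-3-yl gives a 3.9-fold higher number from compound 2 to compound 4 (0.59 log units; beyond the scatter) in a modest move, so among these compounds the steps beyond the scatter are those at the two five-membered rings and not the one on the six-membered ring. Nothing available explains why any of these steps has the size it has.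

Methyl and chloro are the only groups shown on the six-membered ring, so it remains open whether an amine, a carboxylic acid or a longer chain at that carbon would shift the number in this assay more clearly. Going by these compounds, it is also open whether the methyl-to-chloro step would stay this small when paired with thiophen-3-yl or furan-3-yl on the shared core.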